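Iodo Replaced by Cyclopropylmethyl on the Aryl Ring

This account rests on a few compounds, and the source may have more. Where it says the series, first, only, none or still open, it means among the compounds named here.

Compound 2 `CS(=O)(=O)Nc1ccc(CNC(=O)/C=C/c2ccc(I)cc2)cc1F` is recorded in a functional assay (strain Sprague-Dawley) for antagonist activity at transient receptor potential cation channel subfamily V member 1 (Rattus norvegicus) (on this read-out higher numbers stand for weaker inhibition and lower numbers for stronger inhibition), only as a limit, > 10000 nM. Compound 1 `CS(=O)(=O)Nc1ccc(CNC(=O)CCc2ccc(Br)cc2)cc1F` also sits at a limit, > 10000 nM. Compound 3 `CC(C)(C)c1ccc(CCC(=O)NCc2ccc(NS(C)(=O)=O)c(F)c2)cc1`, in contrast, gives a number in this assay, 170 nM. The change leading to compound 4 `CS(=O)(=O)Nc1ccc(CNC(=O)/C=C/c2ccc(CC3CC3)cc2)cc1F` is cyclopropylmethyl in place of iodo on an aromatic carbon. Among the measured compounds shown here, the one measured step that resembles it is an at least 58-fold lower number from compound 1 to compound 3 (1.76 log units; beyond the scatter), likewise a halogen giving way to a branched carbon group on an aromatic carbon; beyond that, the only guide is the limit of > 10000 nM in this assay, at which 2 of the 3 values shown sit. A comparable gain is therefore expected, an at least 33-fold lower number from compound 2 to compound 4 (1.52 log units; beyond the scatter), with the caveat that cyclopropylmethyl is not tert-butyl. Compound 4 is estimated at 300 nM, between 50 nM and 3000 nM.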

Compound 4, half-maximal inhibitory concentration: 390 nM
Compound 4: middle estimate off by 1.3-fold (0.11 log units), on the low side; the measured number falls inside the stated range.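

In this assay, an at least 25-fold lower number from compound 2 to compound 4 (1.40 log units; beyond the scatter) shows that the gain from a carbon group replacing a halogen on this aromatic carbon, para to a large group, is not confined to tert-butyl or to the core of compound 1. Cyclopropylmethyl, with its three-membered ring, gives a large step on the core of compound 2 as well. The true size of that step stays open, since one end of it is only a limit: the limit of > 10000 nM in this assay, at which 2 of the 4 values shown sit.

The compounds shown leave open whether an amine, a carboxylic acid or a longer carbon chain at this position would also give strong inhibition.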